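Adding a Second Chloro to a Fused Purine-like Core

This account rests on a few compounds, and the source may have more. Where it says the series, first, only, none or still open, it means among the compounds named here.

Of the compounds shown here, three sharing a fused two-ring core have been tested in a functional assay on 786-0 cells (Homo sapiens) for cytotoxicity, read by sulforhodamine B assay, with a stated time of 48 h; a lower number here means that less compound is tolerated, a higher number that more compound is tolerated. Compound 1 `ClCc1cccc(Cn2cnc3c(Cl)nc(Cl)nc32)c1` gives 57500 nM, compound 2 `ClCc1ccccc1Cn1cnc2ncnc(Cl)c21` gives 47900 nM, and compound 3 `ClCc1ccc(Cn2cnc3c(Cl)nc(Cl)nc32)cc1` gives 61700 nM. On these numbers compound 2 gives the smallest figure of the three, but the values of compound 1 and compound 3 both lie within the usual scatter of it, so the three compounds cannot be told apart in this assay.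

Compound 4 `ClCc1ccccc1Cn1cnc2nc(Cl)nc(Cl)c21` differs from compound 2 by one change: chloro in place of hydrogen on an aromatic carbon. Within the data shown here, no pair of measured compounds shows this step on its own. Compound 1 and compound 3 already carry two chloro groups on their core and sit close to compound 2 in this assay, which gives no ground to expect movement beyond the scatter. Compound 4 is therefore expected to give about 50000 nM in this assay, somewhere between 25000 nM and 100000 nM, an estimated step of a 1.0-fold higher number from compound 2 to compound 4 (0.02 log units; within the scatter).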

Compound 4, concentration lethal to 50% of the cells: 30900 nM
Beside the measured number, compound 4's estimate is 1.6-fold (0.21 log units) above it, within the range that was stated.
By their numbers in this assay, from the lowest: compounds 4, 2, 1 and 3 (each within the scatter of the next).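

Putting a chloro group in place of hydrogen on the aromatic carbon between two ring nitrogen atoms gives a 1.6-fold lower number from compound 2 to compound 4 (0.19 log units; within the scatter) in this assay, and this step lies within the scatter. Among these compounds, this pair is the first direct reading of the change, since the earlier compounds offered no pair differing only here, and it shows no difference that can be separated from the variation between repeated measurements. Nothing measured here gives a reason for this result.

As far as these compounds go, it remains open whether a different group on this same carbon, such as an amine or a methoxy group, would move the number beyond the scatter. From the compounds shown here alone, it is also open whether the chloro step would look the same on a compound with the chloromethyl group placed elsewhere on its benzene ring.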